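The source may report more compounds than this note shows. Statements on the series, on what has been measured and on what is new or still open speak of the compounds shown alone.

Working notes on the series. Of the compounds shown here, three have so far been measured in a functional assay on HepG2 cells (Homo sapiens) for antiproliferative activity, read by MTT assay, with a stated time of 24 h; a lower number here means a stronger inhibitor, a higher number a weaker inhibitor. Compound 1 `Cc1ccc(-n2cc(-c3ccccc3NS(=O)(=O)c3c[nH]c(=O)[nH]c3=O)nn2)cc1` gives 8350 nM. Compound 2 `O=c1[nH]cc(S(=O)(=O)Nc2ccccc2-c2cn(-c3ccccc3F)nn2)c(=O)[nH]1` gives 12500 nM. For compound 3 `O=c1[nH]cc(S(=O)(=O)Nc2ccccc2-c2cn(-c3ccc(F)cc3)nn2)c(=O)[nH]1` only a limit of the assay is known, > 20000 nM, which is the limit of > 20000 nM in this assay, at which 1 of the 3 values shown sits. Among the measured steps, a 1.5-fold higher number from compound 1 to compound 2 (0.18 log units; within the scatter), an at least 2.3-fold higher number from compound 1 to compound 3 (0.37 log units; beyond the scatter) and an at least 1.6-fold higher number from compound 2 to compound 3 (0.20 log units; that floor lies within the scatter).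

Compound 4 `O=c1[nH]cc(S(=O)(=O)Nc2ccccc2-c2cn(-c3ccccc3Cl)nn2)c(=O)[nH]1` has not been measured; the change from compound 3 is 2-chlorophenyl in place of 4-fluorophenyl on an aromatic nitrogen. The step from compound 2 to compound 3 bears most directly, since it runs the other way between a 2-substituted and a 4-substituted phenyl on that nitrogen, and its floor lies within the scatter. A somewhat lower number is therefore expected, an at least 1.6-fold lower number from compound 3 to compound 4 (0.22 log units; that floor lies within the scatter), though the size is uncertain because compound 3 stands only at a limit. Compound 4 is estimated at 12000 nM, between 5000 nM and 30000 nM.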

Compound 4, half-maximal inhibitory concentration: 2240 nM
The estimate for compound 4 lay 5.4-fold (0.73 log units) above the measured number; measured number below the stated range.
By their numbers in this assay, from the lowest: compound 4; then compounds 1 and 2 (each within the scatter of the next). At a limit, above all of these: compound 3.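

Chloro in place of fluoro on the aromatic carbon alone gives a 5.6-fold lower number from compound 2 to compound 4 (0.75 log units; beyond the scatter) in this assay, so this position responds to the identity of the halogen on the phenyl ring. Against the 4-methylphenyl, the 2-chlorophenyl gives a 3.7-fold lower number from compound 1 to compound 4 (0.57 log units; beyond the scatter), whereas compounds 1 and 2 lie within the scatter of each other. Against the 4-fluorophenyl there is an at least 8.9-fold lower number from compound 3 to compound 4 (0.95 log units; beyond the scatter), which is only a floor, as compound 3 stands at a limit of the assay: the limit of > 20000 nM in this assay, at which 1 of the 4 values shown sits.

Going by these compounds, how a bromophenyl, a methoxyphenyl or an aminophenyl would read in place of the 2-chlorophenyl stays open. Also open, on these data alone, is whether a 4-chlorophenyl would keep the number of compound 4, so the effect of the chloro group cannot yet be separated from that of its place on the ring.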